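From 2,5-dimethoxyphenyl to 3,4-dimethoxyphenyl in compound 1

This account rests on a few compounds, and the source may have more. Where it says the series, first, only, none or still open, it means among the compounds named here.

Among the compounds with values here, compound 1 (`COc1ccc(OC)c(C2=C(c3cc(OC)c(OC)c(OC)c3)C(=O)CC2O[SiH2]C(C)(C)C)c1`) gives 100 ug/mL in an ADME assay on DU-145 cells (Homo sapiens) for cytotoxicity, read by MTT assay, with a stated time of 72 h (a higher number here means a weaker inhibitor, a lower number a stronger inhibitor), the only true number available so far. Compound 2 (`COc1cc(C2=C(c3cc(C)c(OC)c(C)c3)C(O)CC2=O)cc(OC)c1OC`) reports only a limit, > 100 ug/mL. Within the data shown here, no measured step links these two compounds, so compound 1 stands alone as the single numerical anchor.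

Compound 3 (`COc1ccc(C2=C(c3cc(OC)c(OC)c(OC)c3)C(=O)CC2O[SiH2]C(C)(C)C)cc1OC`) has the same atoms as compound 1, joined differently, with 3,4-dimethoxyphenyl in place of 2,5-dimethoxyphenyl on a double-bonded ring carbon. With only compound 1 at 100 ug/mL to go on, no change beyond the usual scatter is expected in this assay, in either direction. The estimated move is a 1.3-fold lower number from compound 1 to compound 3 (0.10 log units; within the scatter), which stays within that scatter. A reading that is only a limit is also expected to be quite possible. For compound 3 the estimate is 80 ug/mL, with an expected range from 30 ug/mL to 150 ug/mL.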

Compound 3, half-maximal inhibitory concentration: > 100 ug/mL
Compound 3 ended at the assay's limit; the forecaster's own chance of this, stated with the estimate: 45%; at least 1.2-fold (0.09 log units) between middle value and limit.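

In this assay compound 3 gives > 100 ug/mL, which is a limit and not a number. Placing 3,4-dimethoxyphenyl instead of 2,5-dimethoxyphenyl on the double-bonded ring carbon gives a number no lower from compound 1 to compound 3 (the limit leaves the size open), so this rearrangement of the two methoxy groups brings no stronger inhibition in this assay, and the size of the step cannot be read. The new reading also adds to the values that rest at the same limit: the limit of > 100 ug/mL in this assay, at which 2 of the 3 values shown sit.

The compounds shown leave open whether a different group on this ring carbon, such as an aminophenyl or a pyridine ring, would bring the number down from the limit. They also leave open whether a plain phenyl ring would read any differently from either dimethoxyphenyl group.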